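The compounds below may be only part of what the source reports. "The series", "measured", "known", "first", "only" and "open" are said of these compounds alone.

Measured so far in an ADME assay on HepG2 cells (Homo sapiens) for cytotoxicity, read by MTT assay, with a stated time of 48 h; a lower number here means a stronger inhibitor, a higher number a weaker inhibitor:
compound 1 `CCN(CC)CCN/C(C)=N\c1ccnc2cc(Cl)ccc12`: 1.32 ug/mL
compound 2 `CC(C)/C(=N/c1ccnc2cc(Cl)ccc12)NCCCN1CCCCC1`: > 24.2 ug/mL (a limit, not a number)
compound 3 `CCN(CC)CCCCN/C(=N\c1ccnc2cc(Cl)ccc12)C(C)C`: 5.01 ug/mL

Compound 3, at 5.01 ug/mL, holds the higher of the two true numbers in the series. Compound 1 holds the lower, at 1.32 ug/mL. For compound 2 there is only a limit: the limit of > 24.2 ug/mL in this assay, at which 1 of the 3 values shown sits.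

Next comes compound 4 `CCN(CC)CCN/C(=N\c1ccnc2cc(Cl)ccc12)C(C)C`, which differs from compound 3 as follows: diethylamino in place of 2-(diethylamino)ethyl on a saturated chain carbon, two bonds along the chain from an amine nitrogen. In words, this is diethylamino in place of 2-(diethylamino)ethyl on a saturated chain carbon, two bonds along the chain from an amine nitrogen.

Among the measured compounds shown here, only one measured step bears on this part of the structure: an at least 4.8-fold lower number from compound 2 to compound 3 (0.68 log units; beyond the scatter). That step put (diethylamino)methyl in place of piperidin-1-yl, which is a different change, so it sets no direct size for this one. For the measured compounds named here, compound 1, at 1.32 ug/mL, is the only measured compound that shares the shorter chain of compound 4, though the two also differ elsewhere. In this assay, a small move toward a lower number is therefore expected, within the scatter rather than beyond it. The expected step is a 1.4-fold lower number from compound 3 to compound 4 (0.16 log units; within the scatter). For compound 4 the estimated value is 3.5 ug/mL, with an expected range of 1.2 ug/mL to 11 ug/mL.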

Compound 4, half-maximal inhibitory concentration: 12.7 ug/mL
Compound 4: middle estimate off by 3.6-fold (0.56 log units), on the low side; measured number above the stated range.
By their numbers in this assay, from the lowest: compound 1; then compound 3; then compound 4. At a limit, above all of these: compound 2.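

The first readable effect of this change alone in this assay is that diethylamino in place of 2-(diethylamino)ethyl on a saturated chain carbon, two bonds along the chain from an amine nitrogen, gives a 2.5-fold higher number from compound 3 to compound 4 (0.40 log units; beyond the scatter) and so here the longer chain carries the lower number. The low number of compound 1 therefore does not follow from the shorter chain, which compound 4 shares; with that chain held, isopropyl in place of methyl on a carbon with a double bond to nitrogen gives a 9.6-fold higher number from compound 1 to compound 4 (0.98 log units; beyond the scatter). Only a floor can be read in an at least 1.9-fold lower number from compound 2 to compound 4 (0.28 log units; that floor lies within the scatter) and no exact size. Compound 2 stands at a limit and not at a number: the limit of > 24.2 ug/mL in this assay, at which 1 of the 4 values shown sits.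

Still open, on these data alone, is whether a diethylamino chain of intermediate length would fall between compound 4 and compound 3, or whether the trend holds for a longer chain, since this reading rests on one pair. Also open, as far as these compounds go, is how far the number moves with an ethyl or a cyclopropyl group on the carbon with a double bond to nitrogen, and whether piperidin-1-yl at the end of the chain in compound 4 would shift the number at all.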